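Swapping the aryl group on the amine of compound 1

The compounds below may be only part of what the source reports. "The series", "measured", "known", "first", "only" and "open" are said of these compounds alone.

Measured compounds:
compound 1 `O=C1C=C(Nc2ccccc2F)C(=O)c2c1nc1n2[C@H]2OC[C@@H](O)[C@H]2OC1`, 5120 nM
compound 2 `Cc1ccc(NC2=CC(=O)c3c(nc4n3[C@H]3OC[C@@H](O)[C@H]3OC4)C2=O)cc1`, 6590 nM
compound 3 `O=C1C(Nc2ccc(C(F)(F)F)cc2)=CC(=O)c2c1nc1n2[C@H]2OC[C@@H](O)[C@H]2OC1`, 8920 nM

In a functional assay on HeLa cells (Homo sapiens) for inhibition, read by sulforhodamine B assay (on this read-out lower numbers stand for stronger inhibition and higher numbers for weaker inhibition), compound 1 gives 5120 nM, the lowest of the three numbers, though its gaps to compound 2 and compound 3 both fall within the usual scatter, so the three compounds cannot be ranked against one another on this evidence.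

The unmeasured compound 4 `O=C1C=C(Nc2cccc(Cl)c2)C(=O)c2c1nc1n2[C@H]2OC[C@@H](O)[C@H]2OC1` differs from compound 1 only in the aryl group attached to the amine nitrogen: 3-chlorophenyl in place of 2-fluorophenyl on an amine nitrogen. Among the measured compounds shown here, no measured pair shows exactly this swap. For the measured compounds named here, the only measured step on the same aryl ring is a 1.4-fold higher number from compound 2 to compound 3 (0.13 log units; within the scatter), which shows that changing the group on that ring left the number essentially where it was. With that single step as the nearest guide, the change from compound 1 to compound 4 is expected to produce no step beyond the scatter in this assay.

Compound 4 is therefore estimated at 5500 nM, within a range of 2500 nM to 12000 nM. That estimate means a step of a 1.1-fold higher number from compound 1 to compound 4 (0.03 log units; within the scatter), expected to stay within the ordinary spread of repeat measurements.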

Compound 4, half-maximal inhibitory concentration: 6040 nM
Beside the measured number, compound 4's estimate is 1.1-fold (0.04 log units) below it; low and high end bracket the measured number.
By their numbers in this assay, from the lowest: compounds 1, 4, 2 and 3 (each within the scatter of the next).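

In this assay, the result is a 1.2-fold higher number from compound 1 to compound 4 (0.07 log units; within the scatter), so compound 1 and compound 4 cannot be told apart on this read-out. This swap changes both the halogen and its place on the aryl ring, whereas the earlier step on that ring replaced methyl with trifluoromethyl, and the aryl group on the amine nitrogen has now been varied in a second way with no step beyond the scatter; across compounds 1, 4, 2 and 3, each number lies within the scatter of the next. No measurement here offers an explanation for this flat result, and a single step cannot show separately what the change of halogen and the change of its place on the ring each contribute.

All four compounds carry a substituted phenyl ring on the amine nitrogen, leaving open how a pyridine ring, a cyclohexyl group or a simple butyl chain would read in that place. Also open, from the compounds shown here alone, is whether a phenyl ring bearing a carboxylic acid or a dimethylamino group would give a step beyond the scatter from compound 1.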